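Pyrimidine substituent variations in a diaryl urea kinase series

The compounds below may be only part of what the source reports. "The series", "measured", "known", "first", "only" and "open" are said of these compounds alone.

Measured compounds:
compound 1 `Nc1cc(Oc2ccc(NC(=O)Nc3cccc(C(F)(F)F)c3)cc2)ncn1` gives 25 nM in an assay on isolated protein for inhibition of serine/threonine-protein kinase TNNI3K (Homo sapiens); a higher number here means a weaker inhibitor, a lower number a stronger inhibitor
compound 2 `CNc1cc(Oc2ccc(NC(=O)Nc3cccc(C(F)(F)F)c3)cc2)ncn1` gives 40 nM in this assay
compound 3 `Cc1cc(Oc2ccc(NC(=O)Nc3cccc(C(F)(F)F)c3)cc2)ncn1` gives 160 nM in this assay

Compound 3 gives the highest number of the three in this assay; its nearest neighbour is compound 2 and its furthest is compound 1, both separated from it beyond the scatter.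

Compound 4 `CN(C)c1cc(Oc2ccc(NC(=O)Nc3cccc(C(F)(F)F)c3)cc2)ncn1` is not yet measured. Its change from compound 3 is dimethylamino in place of methyl on an aromatic carbon, on an aromatic carbon of a six-membered aromatic ring with two nitrogens.

Among the measured compounds shown here, two measured steps bear on this. The step of a 6.4-fold higher number from compound 1 to compound 3 (0.81 log units; beyond the scatter) and the step of a 4.0-fold higher number from compound 2 to compound 3 (0.60 log units; beyond the scatter) both replace a nitrogen substituent at this position with methyl and both raise the number. The change to compound 4 runs the opposite way, restoring a nitrogen substituent, so a lower number is expected in this assay, of a size comparable to those steps. Compound 4 is therefore estimated at 60 nM, with a range from 25 nM to 160 nM, the expected step being a 2.7-fold lower number from compound 3 to compound 4 (0.43 log units; beyond the scatter).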

Compound 4, half-maximal inhibitory concentration: 2500 nM
Compound 4: middle estimate off by 42-fold (1.62 log units), on the low side; the measured number lies above the stated range.
By their numbers in this assay, from the lowest: compounds 1 and 2 (each within the scatter of the next); then compound 3; then compound 4.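

In this assay, a nitrogen substituent at this position does not by itself give a lower number than methyl: dimethylamino goes the other way (a 16-fold higher number from compound 3 to compound 4 (1.19 log units; beyond the scatter)). The second methyl on the nitrogen marks a sharp break, as the first sits within the scatter while the second gives a large rise (a 63-fold higher number from compound 2 to compound 4 (1.80 log units; beyond the scatter)), and the full change from amino is larger still (a 100-fold higher number from compound 1 to compound 4 (2.00 log units; beyond the scatter)). Nothing available explains this rise.

Open, from the compounds shown here alone, is whether the break follows the loss of the last hydrogen on that nitrogen or the presence of a second carbon on it. Ethylamino, which keeps that hydrogen, and a methoxy or ethyl group, which have no such nitrogen, would be informative here, as would a cyclic amine such as azetidine or morpholine.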